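Chloro for Bromo on a Thiol Acrylic Acid Series

A few compounds are considered here, and "the series" means these few. Any claim that something is new, unique, unknown or untested is made for them only; others in the source may bear on it.

The measured compounds:
compound 1, `O=C(O)/C(S)=C/c1c[nH]c2cc(Br)ccc12`, gives 90 nM in an assay on isolated protein for inhibition of Calpain-1 catalytic subunit (Sus scrofa); a higher number here means a weaker inhibitor, a lower number a stronger inhibitor;
compound 2, `O=C(O)/C(S)=C/c1c[nH]c2cc(Cl)ccc12`, gives 100 nM in this assay;
compound 3, `O=C(O)/C(S)=C/c1ccc(Br)cc1`, gives 1500 nM in this assay.

Compound 1 and compound 2 share one core and differ in a single place: chloro in place of bromo on an aromatic carbon. This change made a 1.1-fold higher number from compound 1 to compound 2 (0.05 log units; within the scatter), so the two values are indistinguishable within the usual scatter. Compound 3 carries a different core; how the two cores differ is not broken down here. Its number in this assay is the highest of the three, well beyond the scatter from both compound 1 and compound 2.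

Compound 4, `O=C(O)/C(S)=C/c1ccc(Cl)cc1`, has not yet been measured. It stands to compound 3 as compound 2 stands to compound 1: chloro in place of bromo on an aromatic carbon. The surroundings differ, though. In compound 1 the exchange sits on an aromatic carbon of a six-membered aromatic ring of carbon only, part of a fused or bridged system of two rings, meta to a fused ring and para to a fused ring; in compound 3 it sits on a six-membered aromatic ring of carbon only, para to a group of 6 heavy atoms. So this is the same kind of change, not the same change.

Since the earlier exchange gave a 1.1-fold higher number from compound 1 to compound 2 (0.05 log units; within the scatter), compound 4 is expected to show a 1.1-fold higher number from compound 3 to compound 4 (0.03 log units; within the scatter) in this assay, a step resting on that single precedent and on the shared value of compound 3. Compound 4 is accordingly estimated at 1600 nM, with a likely range from 800 nM to 3500 nM.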

Compound 4, half-maximal inhibitory concentration: 15000 nM
Compound 4: the middle estimate sits 9.4-fold (0.97 log units) below what was measured; the whole stated range lies below it.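

In this assay, chloro in place of bromo on an aromatic carbon gave a 10-fold higher number from compound 3 to compound 4 (1.00 log units; beyond the scatter), whereas the same exchange on the core of compound 1 gave a 1.1-fold higher number from compound 1 to compound 2 (0.05 log units; within the scatter). The two steps do not agree, so in this series the result of the exchange on one core could not be carried over to the other: the same change on two cores in this assay, a 1.1-fold higher number (0.05 log units; within the scatter) from compound 1 to compound 2 and a 10-fold higher number (1.00 log units; beyond the scatter) from compound 3 to compound 4, 9.0-fold (0.95 log units) apart, beyond the scatter of two such steps. This rests on a single pair for each core, and it does not show which difference between the two cores goes with the larger step, whether the core itself or the surroundings of the halogen, nor whether any other exchange at this place would diverge in the same way.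

The compounds shown leave open how a fluoro, iodo, methyl or methoxy group, or plain hydrogen, would read at the same place on either core, and so whether the step from compound 3 to compound 4 belongs to a graded trend across such groups or is particular to this one pair. They also leave open how the exchange would behave on a third core, which could show which of the two steps is the more typical for the series.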